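The compounds below may be only part of what the source reports. "The series", "measured", "known", "first", "only" and "open" are said of these compounds alone.

Measured compounds and their values:

- compound 1, `COc1ccc(C(=O)c2cc(OC)c(OC)c(OC)c2)cc1N`: 2100 nM
- compound 2, `COc1ccc(C(=O)c2cc(OC)c(OC)c(OC)c2)cc1NC(=O)/C=C/c1ccc(F)c(F)c1`: 10200 nM
- compound 3, `COc1ccc(/C=C/C(=O)Nc2cc(C(=O)c3cc(OC)c(OC)c(OC)c3)cc(OC)c2OC)cc1OC`: 7800 nM

In a functional assay on DU-145 cells (Homo sapiens) for cytotoxicity, read by MTT assay, with a stated time of 72 h (on this read-out lower numbers stand for stronger inhibition and higher numbers for weaker inhibition), the three compounds spread over a narrow range. Compound 1, the free amine, gives 2100 nM, and the two cinnamamides lie higher: compound 2 gives 10200 nM and compound 3 gives 7800 nM. Compound 3 thus holds the second highest of the three numbers. Its nearest neighbour is compound 2, whose number is only slightly higher and sits within the scatter of repeated measurements, so the two cinnamamides cannot be told apart on this read-out. Its furthest neighbour is compound 1, whose number is lower by a margin that lies beyond the scatter.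

Compound 4, `COc1cc(C(=O)c2cc(OC)c(OC)c(OC)c2)cc(NC(=O)/C=C/c2ccc(F)cc2)c1OC`, has not yet been measured in this assay. It differs from compound 3 in one place: 4-fluorophenyl in place of 3,4-dimethoxyphenyl on a double-bonded chain carbon bound to a double-bonded chain carbon. The amide, the double bond and the core of compound 3 are kept.

Within the data shown here, no measured pair shows a change of this kind on this core. Among the measured compounds shown here, the only guide is that compound 2, which carries a fluorinated ring on a different core, gives 10200 nM, a number within the scatter of compound 3. On that basis compound 4 is expected to show no step beyond the scatter: the estimated step is a 1.1-fold higher number from compound 3 to compound 4 (0.04 log units; within the scatter). The estimate for compound 4 in this assay is 8500 nM, with a range from 3000 nM to 25000 nM.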

Compound 4, half-maximal inhibitory concentration: 6700 nM
Estimate against measurement, compound 4: 1.3-fold (0.10 log units) above; the range from low to high includes it.
By their numbers in this assay, from the lowest: compound 1; then compounds 4, 3 and 2 (each within the scatter of the next).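

In this assay, among these compounds, putting 4-fluorophenyl in place of 3,4-dimethoxyphenyl on a double-bonded chain carbon bound to a double-bonded chain carbon gives a 1.2-fold lower number from compound 3 to compound 4 (0.07 log units; within the scatter), the first direct reading of a change at this position, and the two compounds cannot be told apart. The group that leaves carries 2 hydrogen-bond acceptors and 10 heavy atoms, while the group that enters carries 0 hydrogen-bond acceptors and 7 heavy atoms, so on this core a swap that differs this much in those counts leaves no step beyond the scatter on this read-out. Nothing at hand accounts for why the two groups read alike.

What the compounds shown leave open is whether a group of another kind on this chain carbon, such as an unsubstituted phenyl, a pyridine ring or a phenyl bearing a carboxylic acid or an amine, would give a step beyond the scatter in this assay. Also open, on these data alone, is whether replacing the double bond with a saturated ethyl chain would leave the number within the scatter of compound 3.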